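This account rests on a few compounds, and the source may have more. Where it says the series, first, only, none or still open, it means among the compounds named here.

Measured so far in a functional assay on A549 cells (Homo sapiens) for cytotoxicity, read by MTT assay, with a stated time of 72 h; on this read-out higher numbers stand for weaker inhibition and lower numbers for stronger inhibition:
compound 1 `COc1cc2c(Oc3ccc(NC(=O)c4cn(-c5ccccc5OC)cn4)cc3F)ccnc2cc1OCCCN1CCN(C)CC1` — 70 nM
compound 2 `COc1cc2c(Oc3ccc(NC(=O)c4cn(-c5cc(C)ccc5C)cn4)cc3F)ccnc2cc1OCCCN1CCN(C)CC1` — 350 nM
compound 3 `COc1cc2c(Oc3ccc(NC(=O)c4cn(-c5ccc(Cl)cc5Cl)cn4)cc3F)ccnc2cc1OCCCN1CCN(C)CC1` — 3850 nM

Compound 2 holds the second highest of the three numbers: compound 1 is nearest, a 5.0-fold higher number from compound 1 to compound 2 (0.70 log units; beyond the scatter), while compound 3 is furthest, an 11-fold higher number from compound 2 to compound 3 (1.04 log units; beyond the scatter). The largest measured step is a 55-fold higher number from compound 1 to compound 3 (1.74 log units; beyond the scatter).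

Compound 4 `COc1cc2c(Oc3ccc(NC(=O)c4cn(-c5cc(C)ccc5C)cn4)cc3F)ccnc2cc1OCCCN1CCC(C)CC1` is not yet measured. It differs from compound 2 by 4-methylpiperidin-1-yl in place of 4-methylpiperazin-1-yl on a saturated chain carbon, three bonds along the chain from an oxygen on an aromatic ring. Within the data shown here, every measured step in this assay concerns the aryl group on the aromatic nitrogen; no pair shows what this chain-end exchange does. Among the measured compounds shown here, there is therefore no measured step that bears on it, and the expectation is for no step beyond the scatter in this assay, in either direction. Compound 4 is accordingly estimated at 350 nM, range 150 nM to 900 nM, which means an expected step of no change at the digits printed from compound 2 to compound 4 (within the scatter).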

Compound 4, half-maximal inhibitory concentration: 7420 nM
Estimate against measurement, compound 4: 21-fold (1.33 log units) below, and the stated range ends below it.
By their numbers in this assay, from the lowest: compound 1; then compound 2; then compounds 3 and 4 (each within the scatter of the next).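

The chain end is not a silent position in this assay: with the 2,5-dimethylphenyl group held constant, 4-methylpiperidin-1-yl in place of 4-methylpiperazin-1-yl gives a 21-fold higher number from compound 2 to compound 4 (1.33 log units; beyond the scatter). Replacing one ring nitrogen with carbon here therefore produces a step also classed as large, like the two steps to the 2,4-dichlorophenyl compound on the aryl side. Nothing available explains this step.

As far as these compounds go, whether the step carries over to the 2-methoxyphenyl compound remains open. So does the outcome with morpholin-4-yl or dimethylamino at the chain end.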